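A Thiophen-2-yl Variant of Compound 3

The compounds below may be only part of what the source reports. "The series", "measured", "known", "first", "only" and "open" are said of these compounds alone.

Compound 3 `O=C(CCCCC[C@H](NC(=O)c1ccc(Br)cc1)C(=O)NCc1ccccc1)NO` stands second highest of the three numbers in a functional assay on NFF cells (Homo sapiens) for antiproliferative activity (on this read-out higher numbers stand for weaker inhibition and lower numbers for stronger inhibition), at 5860 nM. Compound 1 `O=C(CCCCCC(NC(=O)c1cccnc1)C(=O)NCc1ccccc1)NO` gives 24000 nM, and compound 2 `O=C(CCCCC[C@H](NC(=O)c1cc2ccccc2[nH]1)C(=O)NCc1ccccc1)NO` gives 1260 nM. Compound 4 `O=C(CCCCC[C@H](NC(=O)c1cccs1)C(=O)NCc1ccccc1)NO` differs from compound 3 by thiophen-2-yl in place of 4-bromophenyl on a carbonyl carbon. Going by the values given here, the only measured step at this carbonyl carbon is a 4.7-fold higher number from compound 2 to compound 3 (0.67 log units; beyond the scatter), which shows that the group here can shift the number beyond the scatter; it does not involve thiophen-2-yl, so the direction of the present change is uncertain. Compound 4 is therefore expected to land near compound 3, with a step of a 1.2-fold lower number from compound 3 to compound 4 (0.07 log units; within the scatter) judged within or close to the scatter. The estimate for compound 4 is 5000 nM, ranging from 1800 nM to 14000 nM.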

Compound 4, half-maximal inhibitory concentration: 5200 nM
Compound 4: middle estimate off by 1.0-fold (0.02 log units), on the low side; measured number inside the range.
By their numbers in this assay, from the lowest: compound 2; then compounds 4 and 3 (each within the scatter of the next); then compound 1.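

In this assay, thiophen-2-yl in place of 4-bromophenyl on the carbonyl carbon gives a 1.1-fold lower number from compound 3 to compound 4 (0.05 log units; within the scatter) and so leaves the number in place, even though a five-membered aromatic ring with a hetero atom replaces a six-membered ring of carbon only. Thiophen-2-yl in place of 1H-indol-2-yl gives a 4.1-fold higher number from compound 2 to compound 4 (0.62 log units; beyond the scatter) here, so 1H-indol-2-yl stands apart from both other groups in these steps. Nothing available explains either step. The compounds shown leave open whether cyclohexyl on this carbonyl carbon would stay close to compound 4, and whether benzofuran-2-yl would come close to compound 2.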